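A Shorter Acyl Group on the Core of Compound 1

This account rests on a few compounds, and the source may have more. Where it says the series, first, only, none or still open, it means among the compounds named here.

Measured compounds:
compound 1 `O=C(Nc1cc(C(F)(F)F)cc(C(F)(F)F)c1)C1CCc2ccccc2N1C(=O)c1ccc(Cl)cc1` — 4230 nM
compound 2 `CCCCCCCCC(=O)N1c2ccccc2CCC1C(=O)Nc1ccccc1O` — 45200 nM
compound 3 `O=C(Nc1ccccc1C(F)(F)F)C1CCc2ccccc2N1C(=O)c1ccc(Cl)cc1` — 786 nM

In a functional assay on PC-3 cells (Homo sapiens) for cytotoxicity, read by sulforhodamine B assay, with a stated time of 72 h (on this read-out higher numbers stand for weaker inhibition of growth and lower numbers for stronger inhibition of growth), compound 1 gives 4230 nM, the second highest of the three numbers. Compound 3 gives 786 nM, a lower number beyond the scatter, and compound 2 gives 45200 nM, a higher number beyond the scatter; compound 2 differs from compound 1 in more than one place, so no single change can be read from that pair.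

Compound 4 `CCC(=O)N1c2ccccc2CCC1C(=O)Nc1cc(C(F)(F)F)cc(C(F)(F)F)c1` is not yet measured. It differs from compound 1 in one place: ethyl in place of 4-chlorophenyl on a carbonyl carbon. Compound 2, which also carries an alkyl chain on that carbonyl carbon instead of an aromatic ring, shows the highest number in this assay, but its second difference leaves the pairing uncertain.

The step from compound 1 to compound 4 is expected to be a 2.8-fold higher number from compound 1 to compound 4 (0.45 log units; beyond the scatter), towards a higher number, beyond the scatter. For compound 4 the value in this assay is estimated at 12000 nM, within a range from 4000 nM to 40000 nM.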

Compound 4, concentration for 50% growth inhibition: 8540 nM
Beside the measured number, compound 4's estimate is 1.4-fold (0.15 log units) above it; measured number inside the range.
By their numbers in this assay, from the lowest: compound 3; then compound 1; then compound 4; then compound 2.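

For the compounds shown here, this is the first change at this carbonyl carbon that can be read on its own: in this assay, ethyl in place of 4-chlorophenyl gives a 2.0-fold higher number from compound 1 to compound 4 (0.31 log units; beyond the scatter), a modest step. The aromatic ring and its chlorine can therefore be lost from this position at only a modest cost in growth inhibition, with the rest of compound 1 held constant. Nothing shown here accounts for the size of this step.

The compounds leave open whether the step follows from losing the chlorine or the whole ring, as a plain phenyl group is not among them. They also do not show how a longer chain, a cyclopropyl group or an amine on the acyl group would read in this assay with the rest of compound 1 unchanged.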